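The source may hold more compounds than are shown below. What is called first, only, known or untested is meant among the compounds shown, and "the series" means these compounds.

Measured so far, in a functional assay on A549 cells (Homo sapiens) for antiproliferative activity, read by MTT assay, with a stated time of 48 h; on this read-out higher numbers stand for weaker inhibition and lower numbers for stronger inhibition:
Compound 1 `O=c1cc(-n2cc(CNc3ccccc3)nn2)c2cc(Br)ccc2o1` gives 13200 nM.
Compound 2 `Nc1ccc(OCc2cn(-c3cc(=O)oc4ccc(Br)cc34)nn2)cc1` gives 11900 nM.

Compound 2 stands beside compound 1 within the scatter of repeated measurement: the step from compound 1 to compound 2 is a 1.1-fold lower number from compound 1 to compound 2 (0.05 log units; within the scatter), so no difference between the two can be claimed. Compound 3 `COC(=O)c1ccc(OCc2cn(-c3cc(=O)oc4ccc(Br)cc34)nn2)cc1` differs from compound 2 by methoxycarbonyl in place of amino on an aromatic carbon. Among the compounds with values here, the only measured step, a 1.1-fold lower number from compound 1 to compound 2 (0.05 log units; within the scatter), changes the link between the outer ring and the shared core, not a group on that ring, so it does not bear on this change. With nothing to suggest movement, no step beyond the scatter is expected: a 1.0-fold higher number from compound 2 to compound 3 (0.00 log units; within the scatter). Compound 3 is therefore estimated at 12000 nM, with a range from 4000 nM to 36000 nM.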

Compound 3, half-maximal inhibitory concentration: 660 nM
Beside the measured number, compound 3's estimate is 18-fold (1.26 log units) above it, and the stated range ends above it.
By their numbers in this assay, from the lowest: compound 3; then compounds 2 and 1 (each within the scatter of the next).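

In this assay, the group on this six-membered aromatic ring, para to a large group, strongly affects the read-out: methoxycarbonyl in place of amino gives an 18-fold lower number from compound 2 to compound 3 (1.26 log units; beyond the scatter) on this ring. The entering group is larger and has no hydrogen-bond donor, so this single pair cannot separate those two differences. Nothing available gives a reason for the step.

From the compounds shown here alone, whether methoxycarbonyl itself is required remains open. A carboxylic acid, a primary amide or a methyl group at the same place would show which features track with the read-out.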